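Taking the Hydroxy Group Off Compound 3

The source may report more compounds than this note shows. Statements on the series, on what has been measured and on what is new or still open speak of the compounds shown alone.

In a functional assay on PANC-1 cells (Homo sapiens) for antiproliferative activity, read by MTT assay, with a stated time of 48 h (a lower number here means a stronger inhibitor, a higher number a weaker inhibitor), compound 1 `COc1ccc(-c2c(Nc3ccc(C)c(O)c3)c3ccccc3oc2=O)cc1` gives 9750 nM, while compound 3 `COc1ccc(-c2c(Nc3ccc(C)c(O)c3)c3ccc(OC)cc3oc2=O)cc1` gives 31300 nM, the higher of the two numbers and so the weaker result. Compound 2 `COc1ccc(-c2c(Nc3ccc(F)cc3)c3ccc(OC)cc3oc2=O)cc1` offers no comparison, as its entry reads "not determined" (no result reported).

Compound 4 `COc1ccc(-c2c(Nc3ccc(C)cc3)c3ccc(OC)cc3oc2=O)cc1` differs from compound 3 by one change, hydrogen in place of hydroxy on an aromatic carbon. The 3-hydroxy-4-methylphenyl group becomes 4-methylphenyl.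

For the measured compounds named here, the only measured step, a 3.2-fold higher number from compound 1 to compound 3 (0.51 log units; beyond the scatter), is methoxy in place of hydrogen on an aromatic carbon. Going by the values given here, that is a different change, and no measured pair shows what losing the hydroxy does. Going by these compounds, this modest step therefore serves only as a rough guide to size, and the direction stays open in this assay. The estimated step is a 1.1-fold higher number from compound 3 to compound 4 (0.05 log units; within the scatter), which is expected to stay within the scatter. The estimate for compound 4 is 35000 nM, with an expected range of 12000 nM to 100000 nM.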

Compound 4, half-maximal inhibitory concentration: 76500 nM
The estimate for compound 4 lay 2.2-fold (0.34 log units) below the measured number; the range from low to high includes it.
By their numbers in this assay, from the lowest: compound 1; then compound 3; then compound 4.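

Taking away the hydroxy turns the 3-hydroxy-4-methylphenyl group into 4-methylphenyl and weakens the result in this assay (a 2.4-fold higher number from compound 3 to compound 4 (0.39 log units; beyond the scatter)), a modest step beyond the scatter. Compound 1 and compound 3 both carry this hydroxy, so they could not show what it contributes; this pair shows that, on the core of compound 3, the stronger number goes with having it. No measurement here gives a reason for the step.

Going by these compounds, what an amine or a carboxylic acid would do in place of the hydroxy stays open. On these data alone, it is also open whether losing the hydroxy would give a step of similar size on the core of compound 1, which has hydrogen where compound 3 has its added methoxy.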